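Compound 4: Replacing the Benzamide Carbonyl with a Benzyl Link

The compounds below may be only part of what the source reports. "The series", "measured", "known", "first", "only" and "open" are said of these compounds alone.

Among the compounds with values here, compound 1 `O=C(CN(C(=O)c1ccc(Cl)cc1)C1CCCCC1)Nc1cc(F)cc(F)c1` gives 631 nM in an assay on HEK293 cells for inhibition of sodium- and chloride-dependent glycine transporter 1 (Homo sapiens), read by scintillation proximity assay (a lower number here means a stronger inhibitor, a higher number a weaker inhibitor), the lowest of the three numbers measured so far. Compound 2 `CC(C(=O)Nc1cc(F)cc(F)c1)N(C(=O)c1ccc(Cl)cc1)C1CCCCC1` gives 3980 nM, and compound 3 `O=C(CCN(C(=O)c1ccc(Cl)cc1)C1CCCCC1)Nc1cc(F)cc(F)c1` gives 10000 nM. Both of those steps altered the chain; the step of a 6.3-fold higher number from compound 1 to compound 2 (0.80 log units; beyond the scatter) was modest but beyond the scatter, and compound 3 stands further away still. Compound 4 `O=C(CN(Cc1ccc(Cl)cc1)C1CCCCC1)Nc1cc(F)cc(F)c1` differs from compound 1 elsewhere: 4-chlorobenzyl in place of (4-chlorophenyl)carbonyl on an amine nitrogen. Within the data shown here, no measured step touches this part of the shared core, so the expectation rests on nothing closer than the observation that every change made to compound 1 so far has raised the number. A rise is therefore expected for compound 4, of roughly a 6.3-fold higher number from compound 1 to compound 4 (0.80 log units; beyond the scatter), and its value in this assay is estimated at 4000 nM, with a range from 1000 nM to 16000 nM.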

Compound 4, half-maximal inhibitory concentration: > 25100 nM
Compound 4: a limit, no number; the forecaster's own chance of this, stated with the estimate: 20%; middle value at least 6.2-fold (0.79 log units) from the limit.
By their numbers in this assay, from the lowest: compound 1; then compound 2; then compound 3. At a limit, above all of these: compound 4.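

Within the data shown here, replacing (4-chlorophenyl)carbonyl with 4-chlorobenzyl on the amine nitrogen gives an at least 39-fold higher number from compound 1 to compound 4 (1.59 log units; beyond the scatter), so the first change at this position shows that the number in this assay depends on more than the chain. With the ring and chlorine retained, the carbonyl of compound 1 appears to matter here. Compound 4 has a limit and not a number: the limit of > 25100 nM in this assay, at which 1 of the 4 values shown sits.

The compounds shown leave open whether a sulfonyl or urea link on this nitrogen would keep the number close to that of compound 1. They also leave open whether the carbonyl could be replaced at all.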